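Branched Chain to Small Ring on the Aromatic Nitrogen

The compounds below may be only part of what the source reports. "The series", "measured", "known", "first", "only" and "open" are said of these compounds alone.

Of the compounds shown here, three with a shared core have been tested in an assay on cell membranes for displacement of a labelled ligand from corticotropin-releasing factor receptor 1 (Rattus norvegicus); a higher number here means a weaker inhibitor, a lower number a stronger inhibitor. Compound 1 `CCOCC(COCC)Nc1nc(C)nc2c(-c3ccc(OC)cc3C)c(C)nn12` gives 19.3 nM. Compound 2 `CCN(CC)c1nc(C)nc2c(-c3cc(OC)c(OC)cc3Br)c(C)nn12` gives 4.06 nM in this assay. Compound 3 `CCCC(C)Nc1nc(C)nc2c(-c3c(C)cc(OC)cc3OC)c(C)nn12` gives 2.14 nM in this assay.

Among these three numbers, the one for compound 3 is the lowest. Its gap to compound 2 lies within the usual scatter, so the two cannot be ranked against each other. Its gap to compound 1 lies beyond the scatter, and compound 1 is the furthest of the three from compound 3.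

Compound 4 `COc1cc(C)c(-c2c(C)nn3c(NC4CCC4)nc(C)nc23)c(OC)c1` has not yet been measured. It differs from compound 3 in one place: cyclobutyl in place of 1-methylbutyl on a nitrogen on an aromatic ring. For the measured compounds named here, no pair of measured compounds isolates this change, so there is no measured step to lean on. Both groups carry no hydrogen-bond donors or acceptors and no charge, and the counts of heavy atoms are close, so only a small step is expected, likely none beyond the scatter, in either direction. Compound 4 is therefore estimated at 3.5 nM in this assay, within a range of 1.2 nM to 10 nM. The expected step is a 1.6-fold higher number from compound 3 to compound 4 (0.21 log units; within the scatter).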

Compound 4, half-maximal inhibitory concentration: 17.4 nM
Estimate against measurement, compound 4: 5.0-fold (0.70 log units) below; measured number outside the range, above it.
By their numbers in this assay, from the lowest: compounds 3 and 2 (each within the scatter of the next); then compounds 4 and 1 (each within the scatter of the next).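

In this assay, for the compounds shown here, the exchange of 1-methylbutyl for cyclobutyl on the nitrogen on an aromatic ring gives an 8.1-fold higher number from compound 3 to compound 4 (0.91 log units; beyond the scatter) and is the only measured step here that isolates a single change. It shows that this position is sensitive to the shape of a purely carbon group: the two groups match in having no hydrogen-bond donors or acceptors and no net charge, and differ by little in heavy-atom count, yet the step lies beyond the scatter, which the three earlier compounds, differing from one another in several places at once, could not reveal. Nothing measured here accounts for the size of this step.

The compounds shown leave open whether the step follows from the ring itself or from the shorter carbon framework, a question that a cyclopentyl or a 1-methylpropyl group on the same nitrogen would help to separate. From the compounds shown here alone, it also remains open whether a step of this size would recur with the other aromatic groups carried by compound 1 and compound 2.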